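A few compounds are considered here, and "the series" means these few. Any claim that something is new, unique, unknown or untested is made for them only; others in the source may bear on it.

Measured compounds:
compound 1 `O=C(O)c1coc2ccc(OCc3cccc(Br)c3)cc2c1=O`: 2.8 nM
compound 2 `O=Cc1coc2ccc(OCc3cccc(Br)c3)cc2c1=O`: 3.7 nM

In an assay on isolated protein for inhibition of Amine oxidase [flavin-containing] B (Homo sapiens), read by fluorescence, with a stated time of 20 min (on this read-out higher numbers stand for weaker inhibition and lower numbers for stronger inhibition), compound 2 holds the higher of these two numbers, yet the step of a 1.3-fold higher number from compound 1 to compound 2 (0.12 log units; within the scatter) stays within the scatter, so compound 1 and compound 2 are not told apart. Compound 3 `COC(=O)c1coc2ccc(OCc3cccc(Br)c3)cc2c1=O` differs from compound 2 in one place: methoxy in place of hydrogen on a carbonyl carbon. Going by the values given here, the only measured step touches the same carbonyl carbon, where hydroxy and hydrogen gave numbers within the scatter of each other. A methoxy there is therefore expected to move the number little, with the step of a 1.2-fold higher number from compound 2 to compound 3 (0.09 log units; within the scatter) expected to stay within the scatter. Compound 3 is estimated at 4.5 nM, in the range 1.5 nM to 14 nM.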

Compound 3, half-maximal inhibitory concentration: 77.4 nM
Compound 3: the middle estimate sits 17-fold (1.24 log units) below what was measured; measured number outside the range, above it.
By their numbers in this assay, from the lowest: compounds 1 and 2 (each within the scatter of the next); then compound 3.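

In this assay, this carbonyl carbon turns out not to accept every group alike: methoxy in place of hydrogen gives a 21-fold higher number from compound 2 to compound 3 (1.32 log units; beyond the scatter), and methyl in place of hydrogen on the oxygen gives a 28-fold higher number from compound 1 to compound 3 (1.44 log units; beyond the scatter). Hydroxy and hydrogen could not be told apart here, so that earlier pair gave no sign that a change at this place could matter so much. Nothing available here bears on what lies behind this loss of inhibition.

Going by these compounds, whether an amine or an ethoxy on this carbonyl carbon would read like hydroxy and hydrogen or like methoxy stays open.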